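A Ring Swap at the Far End of Compound 1

The source may hold more compounds than are shown below. What is called first, only, known or untested is meant among the compounds shown, and "the series" means these compounds.

Measured so far:
Compound 1 `COc1ccccc1/C=C/C(=O)c1ccc(OCC(=O)N[C@H]2CCOC2=O)cc1` gives > 64000 nM in a functional assay on MCF7 cells (Homo sapiens) for antiproliferative activity, read by MTT assay, with a stated time of 72 h; a higher number here means a weaker inhibitor, a lower number a stronger inhibitor; this is a limit of the assay, not a number.
Compound 2 `CCCCCCCCCCSC(=S)N[C@H]1CCOC1=O` gives > 64000 nM in this assay; this too is a limit of the assay.
Compound 3 `O=C1OCC[C@@H]1NC(=S)SCCOc1ccccc1Cc1ccccc1` gives 39500 nM in this assay.

Compound 1 therefore stands at the limit of > 64000 nM in this assay, at which 2 of the 3 values shown sit, and compound 3 is the only one of the three with a counted number, itself a weak one. Every compound here carries the same small lactone-bearing amide end, and none of them shows any real strength in this assay.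

Compound 4 `O=C(COc1ccc(C(=O)/C=C/c2ccc(F)c(F)c2)cc1)N[C@H]1CCOC1=O` is the compound to be measured next. It differs from compound 1 in one place: 3,4-difluorophenyl in place of 2-methoxyphenyl on a double-bonded chain carbon bound to a double-bonded chain carbon. Among the compounds with values here, no pair of measured compounds differs in a single place, so no measured step can guide the size of this change. With compound 1 at its limit and the other two compounds also weak, the expectation is that compound 4 stays in the same weak region, with a step of an at least 1.2-fold lower number from compound 1 to compound 4 (0.10 log units; that floor lies within the scatter) expected rather than any move beyond the scatter. Compound 4 is estimated at 50000 nM, within a range from 15000 nM to 200000 nM.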

Compound 4, half-maximal inhibitory concentration: > 64000 nM
Compound 4 gave a limit, no number; the forecaster's own chance of this, stated with the estimate: 60%; middle value at least 1.2-fold (0.10 log units) away from the limit.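

Within the data shown here, compound 1 and compound 4 both end at a limit of the assay rather than at a number, and no step between them can be read. The values shown gather at a single point: the limit of > 64000 nM in this assay, at which 3 of the 4 values shown sit. On these data alone, whether 3,4-difluorophenyl in place of 2-methoxyphenyl changes the strength in this assay at all remains open.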